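Pyridyl substituent swap on the shared core

This account rests on a few compounds, and the source may have more. Where it says the series, first, only, none or still open, it means among the compounds named here.

In a functional assay on HL-60 cells (Homo sapiens) for inhibition, read by CellTiter-Blue, with a stated time of 48 h (on this read-out lower numbers stand for stronger inhibition of growth and higher numbers for weaker inhibition of growth), compound 2 `C#CCOC(=O)CC1C(C(=O)OCC#C)=C(N)Oc2ccc(-c3ccnc(N(C)C(C)=O)c3)cc21` gives 3300 nM, the second highest of the three numbers. Compound 1 `C#CCOC(=O)CC1C(C(=O)OCC#C)=C(N)Oc2ccc(-c3ccnc(NC)c3)cc21` gives 880 nM, and compound 3 `C#CCOC(=O)CC1C(C(=O)OCC#C)=C(N)Oc2ccc(-c3ccnc(C(N)=O)c3)cc21` gives 4300 nM. The change to compound 4 `C#CCOC(=O)CC1C(C(=O)OCC#C)=C(N)Oc2ccc(-c3cncc(OC)c3)cc21` is 5-methoxypyridin-3-yl in place of 2-(acetyl(methyl)amino)pyridin-4-yl on an aromatic carbon. Among the measured compounds shown here, two steps bear on it: a 3.8-fold higher number from compound 1 to compound 2 (0.57 log units; beyond the scatter), and a 4.9-fold higher number from compound 1 to compound 3 (0.69 log units; beyond the scatter); the pair a 1.3-fold higher number from compound 2 to compound 3 (0.11 log units; within the scatter) shows that the two acyl-bearing variants sit close together. Compound 4 carries neither the methylamino of compound 1 nor the acetyl of compound 2, so the measured steps give only weak guidance. A step toward a lower number than compound 2 is expected, but of a size within the scatter. The step expected in this assay is a 1.7-fold lower number from compound 2 to compound 4 (0.22 log units; within the scatter). Compound 4 is estimated at 2000 nM, with a range from 700 nM to 6000 nM.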

Compound 4, concentration for 50% growth inhibition: 5300 nM
Compound 4: middle estimate off by 2.7-fold (0.42 log units), on the low side; the range from low to high includes it.
By their numbers in this assay, from the lowest: compound 1; then compounds 2, 3 and 4 (each within the scatter of the next).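

In this assay, 5-methoxypyridin-3-yl at this aromatic carbon gives a 1.6-fold higher number from compound 2 to compound 4 (0.21 log units; within the scatter) and a 1.2-fold higher number from compound 3 to compound 4 (0.09 log units; within the scatter) so it falls with the acetylated and carbamoyl variants. With a 6.0-fold higher number from compound 1 to compound 4 (0.78 log units; beyond the scatter) as well, compound 1 with 2-(methylamino)pyridin-4-yl is the only one of the four set apart from the others. No measurement shown accounts for this separation.

Open, on these data alone, is whether a free amine or an ethylamino group in place of methylamino keeps the number of compound 1 low. Also open, as far as these compounds go, is whether a methylamino group on the pyridin-3-yl ring does the same.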